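Dropping a Methoxy from a Bis-furan Amidine

This account rests on a few compounds, and the source may have more. Where it says the series, first, only, none or still open, it means among the compounds named here.

Compound 1 `COc1ccc(-c2ccc(-c3ccc(C(=N)N)o3)o2)cc1` was tested in a functional assay on EKVX cells (Homo sapiens) for inhibition, read by sulforhodamine B assay, with a stated time of 48 h (on this read-out lower numbers stand for stronger inhibition of growth and higher numbers for weaker inhibition of growth), and gave 2790 nM. Compound 2 `N=C(N)c1ccc(-c2ccc(-c3ccc(Cl)cc3)s2)s1` gave 1640 nM, and compound 3 `COc1cc(OC)cc(-c2ccc(-c3ccc(C(=N)N)o3)o2)c1` gave 5090 nM. Compound 1 thus stands second highest of the three numbers; its nearest neighbour is compound 2 and its furthest is compound 3, yet both gaps lie within the scatter of repeated measurements, so no ranking can be read from them. Compound 4 `N=C(N)c1ccc(-c2ccc(-c3ccccc3)o2)o1` has not yet been measured. It differs from compound 1 in one place: hydrogen in place of methoxy on an aromatic carbon. Among the measured compounds shown here, with no step between measured compounds to lean on, the expected step of a 1.1-fold higher number from compound 1 to compound 4 (0.03 log units; within the scatter) is small, in no firm direction, and not beyond the scatter. Compound 4 is therefore expected to give about 3000 nM, between 1200 nM and 7500 nM.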

Compound 4, concentration for 50% growth inhibition: 2340 nM
Compound 4: middle estimate off by 1.3-fold (0.11 log units), on the high side, and the stated range covers the measured number.
By their numbers in this assay, from the lowest: compounds 2, 4, 1 and 3 (each within the scatter of the next, the first and the last beyond it).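

In this assay, hydrogen in place of methoxy gives a 1.2-fold lower number from compound 1 to compound 4 (0.08 log units; within the scatter) and so no readable change. Among the compounds shown here, this is the first direct test of this position, para to a large group, and it shows that growth inhibition in these cells holds with the methoxy gone. No measured evidence on hand accounts for this result.

A single swap says little about the position as a whole. As far as these compounds go, whether a different group there, such as an amine or a carboxylic acid, would shift the number beyond the scatter remains open.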